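Aryl amide variation on the shared core: efficacy notes

A few compounds are considered here, and "the series" means these few. Any claim that something is new, unique, unknown or untested is made for them only; others in the source may bear on it.

Measured compounds:
compound 1, `Cc1cc(C(=O)NCN2CCC(c3cccc[n+]3[O-])CC2)ccc1F`: 67%
compound 2, `C=Cc1cccc(C(=O)NCN2CCC(c3cccc[n+]3[O-])CC2)c1`: 63%
compound 3, `CCOc1cccc(C(=O)NCN2CCC(c3cccc[n+]3[O-])CC2)c1`: 54%

In a functional assay on HEK293 cells for agonist activity at D(4) dopamine receptor (Homo sapiens), read by FLIPR (a lower number here means a smaller maximal response, a higher number a larger maximal response), compound 2 gives 63%, which stands second highest of the three numbers. Its nearest neighbour is compound 1, and the step of a number 4 percentage points lower from compound 1 to compound 2 (within the scatter) lies within the scatter. The furthest is compound 3, reached by a number 9 percentage points lower from compound 2 to compound 3 (within the scatter), again within the scatter. Both measured steps exchange the aryl group on the carbonyl carbon, and neither moves the maximal response beyond the scatter.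

Compound 4, `O=C(NCN1CCC(c2cccc[n+]2[O-])CC1)c1ccccn1`, continues this series of exchanges: pyridin-2-yl in place of 3-vinylphenyl on a carbonyl carbon. The two steps that bear on it, a number 4 percentage points lower from compound 1 to compound 2 (within the scatter) and a number 9 percentage points lower from compound 2 to compound 3 (within the scatter), were both small, so for this assay no step beyond the scatter is expected, and the expected step is a number 5 percentage points lower from compound 2 to compound 4 (within the scatter), leaning slightly lower in line with the two measured steps. Among the measured compounds shown here, no measured compound carries a nitrogen in that ring, so the range is kept wide. Compound 4 is thus expected to give 58%, between 42% and 74%.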

Compound 4, largest response reached (reported as efficacy), in percent of the reference or control that the assay uses: 40%
Compound 4: middle estimate off by 18 percentage points, on the high side, outside the stated range (below it).
By their numbers in this assay, from the lowest: compound 4; then compounds 3, 2 and 1 (each within the scatter of the next, the first and the last beyond it).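

In this assay this position on the carbonyl carbon can move the maximal response beyond the scatter, which the earlier exchanges did not show: pyridin-2-yl gives a number 23 percentage points lower from compound 2 to compound 4 (beyond the scatter) and a number 27 percentage points lower from compound 1 to compound 4 (beyond the scatter). The change is also not a clean split between the two kinds of ring, since compound 3, with a ring of carbon only, stands within the scatter of compound 4. Nothing at hand accounts for the lower response of compound 4.

Compound 4 differs from the others both in its ring nitrogen and in carrying no further substituent on that ring, so the two cannot be told apart here. Unsubstituted phenyl, pyridin-3-yl and pyridin-4-yl at this position would separate them, and a methyl-substituted pyridin-2-yl would show whether a substituent restores the response.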